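Compound 3: A Lactam Replaces a Fluorinated Sulfur Group

The source may report more compounds than this note shows. Statements on the series, on what has been measured and on what is new or still open speak of the compounds shown alone.

Compound 1, `Cc1noc(-c2nc(C)c3c(c2N)C(=O)N(Cc2ccc(OC(F)F)cc2)C3=O)n1`, gives < 5000 nM in a physicochemical assay for solubility, using the shake flask method, in simulated intestinal fluid, measured as kinetic solubility, with a stated time of 2 h, at 25 degrees C, at pH 6.5 (a lower number here means a less soluble compound, a higher number a more soluble compound), and this is a limit rather than a number. Compound 2, `Cc1noc(-c2nc(C)c3c(c2N)C(=O)N(Cc2ccc(SC(F)(F)F)cc2)C3=O)n1`, gives < 5000 nM, which is also a limit. The two compounds therefore share the same position on the scale: the limit of < 5000 nM in this assay, at which 2 of the 2 values shown sit. For the measured compounds named here, the only measured step is a step that the two limits leave unreadable from compound 1 to compound 2, so it offers no size to carry forward.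

Compound 3, `Cc1noc(-c2nc(C)c3c(c2N)C(=O)N(Cc2ccc(N4CCCC4=O)cc2)C3=O)n1`, carries 2-oxopyrrolidin-1-yl in place of the (trifluoromethyl)sulfanyl of compound 2, on an aromatic carbon of a six-membered aromatic ring of carbon only, para to a large group: 2-oxopyrrolidin-1-yl in place of (trifluoromethyl)sulfanyl on an aromatic carbon. The fluorine and sulfur atoms leave, and a five-membered non-aromatic ring enters. This is a different kind of swap from the one between the two measured compounds, and the expectation in this assay rests on the structures alone. A modest upward move is expected, held with little confidence, and another limit would be no surprise. The estimated change is an at least 1.6-fold higher number from compound 2 to compound 3 (0.20 log units; that floor lies within the scatter). For compound 3 the expected value is 8000 nM, within an estimated range of 2000 nM to 40000 nM.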

Compound 3, solubility: < 5000 nM
Compound 3 gave a limit, no number; the forecaster's own chance of this, stated with the estimate: 45%; middle value at least 1.6-fold (0.20 log units) from the limit.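

No step among compound 1, compound 2 and compound 3 can be read, as each value is a limit and not a number: the limit of < 5000 nM in this assay, at which 3 of the 3 values shown sit.

The compounds shown leave open where any of the three truly stands in this assay, and whether swapping the group on the aromatic carbon changes the read-out at all.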